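This account rests on a few compounds, and the source may have more. Where it says the series, first, only, none or still open, it means among the compounds named here.

Working notes on the series. Compound 1 `O=C(O)CC/C=C\CC1COC(c2ccccc2Cl)OC1c1cccnc1` gives 48 nM in an assay for inhibition of Thromboxane-A synthase (Homo sapiens), using microsomes; on this read-out lower numbers stand for stronger inhibition and higher numbers for weaker inhibition. Compound 2 `O=C(O)CC/C=C\CC1COC(c2ccc(C(F)(F)F)cc2)OC1c1cccnc1` gives 44 nM in this assay, and compound 3 `O=C(O)CC/C=C\CC1COC(c2cccnc2)OC1c1cccnc1` gives 220 nM. Compound 2 holds the lowest number of the three, but its step from compound 1 lies within the scatter: a 1.1-fold lower number from compound 1 to compound 2 (0.04 log units; within the scatter). Its step to compound 3 lies beyond it: a 5.0-fold higher number from compound 2 to compound 3 (0.70 log units; beyond the scatter), and the same exchange starting from compound 1 reads a 4.6-fold higher number from compound 1 to compound 3 (0.66 log units; beyond the scatter).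

Compound 4 `O=C(O)CC/C=C\CC1COC(c2ccco2)OC1c1cccnc1` is not yet measured. It differs from compound 2 in one place: furan-2-yl in place of 4-(trifluoromethyl)phenyl on a saturated ring carbon. Within the data shown here, three measured steps bear on this change. Exchanging one aromatic ring of carbon only for another left the number unchanged within the scatter, whereas the two exchanges of a carbon-only ring for an aromatic ring with one hetero atom raised the number modestly. The group entering compound 4 is also an aromatic ring with one hetero atom and one acceptor, though five-membered rather than six-membered, and the precedent rests on a single compound, compound 3. Compound 4 is therefore expected to show a 2.7-fold higher number from compound 2 to compound 4 (0.44 log units; beyond the scatter) in this assay. The estimate for compound 4 is 120 nM, with a range from 50 nM to 300 nM.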

Compound 4, half-maximal inhibitory concentration: 164 nM
The estimate for compound 4 lay 1.4-fold (0.14 log units) below the measured number; measured number inside the range.
By their numbers in this assay, from the lowest: compounds 2 and 1 (each within the scatter of the next); then compounds 4 and 3 (each within the scatter of the next).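

In this assay, furan-2-yl reads level with pyridin-3-yl (a 1.3-fold lower number from compound 3 to compound 4 (0.13 log units; within the scatter)), so at this saturated ring carbon between two ring oxygen atoms, a five-membered and a six-membered aromatic ring with one hetero atom cannot be told apart. The rise seen earlier with pyridin-3-yl now has a second example, as furan-2-yl also stands above both carbon-only aromatic groups, 4-(trifluoromethyl)phenyl (a 3.7-fold higher number from compound 2 to compound 4 (0.57 log units; beyond the scatter)) and 2-chlorophenyl (a 3.4-fold higher number from compound 1 to compound 4 (0.53 log units; beyond the scatter)), and none of the four compounds goes against this split. Nothing at hand gives a reason for the split between these two pairs of groups.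

Both carbon-only rings here carry a substituent, chlorine or trifluoromethyl, while both rings with a hetero atom carry none, so the hetero atom and the missing substituent cannot be separated; an unsubstituted phenyl would address this directly. Also open, on these data alone, is whether a thiophen-2-yl ring, with sulfur in place of the furan oxygen, or a chlorine or trifluoromethyl group placed on the furan-2-yl or pyridin-3-yl ring would follow the same split.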